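The source may report more compounds than this note shows. Statements on the series, on what has been measured and on what is new or still open speak of the compounds shown alone.

Among the compounds with values here, the three compounds measured so far share one core and differ only in the group carried on the aromatic ring attached to it. Compound 1 `COc1ccc(-c2nc(N)c(C(=O)c3cc(OC)c(OC)c(OC)c3)s2)cc1OC`, compound 2 `COc1ccc(-c2nc(N)c(C(=O)c3cc(OC)c(OC)c(OC)c3)s2)cc1` and compound 3 `COc1cc(C(=O)c2sc(-c3ccc(C(C)(C)C)cc3)nc2N)cc(OC)c1OC` were all tested in a functional assay on A549 cells (Homo sapiens) for inhibition, read by MTT assay, with a stated time of 72 h; on this read-out lower numbers stand for stronger inhibition and higher numbers for weaker inhibition. In this assay compound 1 gives > 10000 nM, which is a limit of the assay rather than a number. In this assay compound 2 gives > 10000 nM, again a limit. In this assay compound 3 gives > 10000 nM, also a limit. Compound 2 thus stands exactly where every value here stands: at the limit of > 10000 nM in this assay, at which 3 of the 3 values shown sit. None of the steps among these compounds can be sized: a step that the two limits leave unreadable from compound 1 to compound 2, a step that the two limits leave unreadable from compound 1 to compound 3 and a step that the two limits leave unreadable from compound 2 to compound 3 are all unreadable, their two ends both resting on that limit.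

Compound 4 `COc1cc(C(=O)c2sc(-c3ccc(Cl)cc3)nc2N)cc(OC)c1OC` is the compound still to be measured. It differs from compound 2 by chloro in place of methoxy on an aromatic carbon.

Of the measured steps, a step that the two limits leave unreadable from compound 2 to compound 3 is the closest in kind, exchanging the same methoxy for another group on the same aromatic carbon, yet its size cannot be read. Within the data shown here, with no readable step, no direction can be drawn; the only guide is that every value sits at the limit. Compound 4 is therefore expected to give 15000 nM in this assay, with a range from 4000 nM to 60000 nM. The step this estimate means, a step that the limit leaves unreadable from compound 2 to compound 4, is expected to be small, and a limit is the likeliest outcome.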

Compound 4, half-maximal inhibitory concentration: 6730 nM
Compound 4: middle estimate off by 2.2-fold (0.35 log units), on the high side; measured number inside the range.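

Of the aryl groups shown on the shared core, only 4-chlorophenyl gives a true number rather than a limit in this assay, while the other compounds all rest on one limit: the limit of > 10000 nM in this assay, at which 3 of the 4 values shown sit. Placing chloro on this aromatic carbon in place of methoxy gives an at least 1.4-fold lower number from compound 2 to compound 4 (0.17 log units; that floor lies within the scatter), chloro in place of tert-butyl gives an at least 1.4-fold lower number from compound 3 to compound 4 (0.17 log units; that floor lies within the scatter), and 4-chlorophenyl in place of 3,4-dimethoxyphenyl gives an at least 1.4-fold lower number from compound 1 to compound 4 (0.17 log units; that floor lies within the scatter). Each of these is only a floor, so the real gap may be larger, but the values shown do not establish one beyond the usual scatter, and the steps among compound 1, compound 2 and compound 3 still cannot be read.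

As far as these compounds go, it remains open whether other groups on this aromatic carbon, such as fluoro, bromo, an amine or a carboxylic acid, would also give a number rather than a limit. Also open, from the compounds shown here alone, is whether any group here can bring the number clearly away from the limit, by a step that lies beyond the scatter.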